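Hydrazone series: replacing the aryl hydrazone with methyl

The source may report more compounds than this note shows. Statements on the series, on what has been measured and on what is new or still open speak of the compounds shown alone.

Measured so far:
compound 1, `Cc1cccc(NN=C2CCC(C)n3c2ncc(C(=O)O)c3=O)c1C`, > 100 umol/kg
compound 2, `CCOC(=O)c1cnc2n(c1=O)C(C)CCC2=NNc1c(C)n(C)n(-c2ccccc2)c1=O`, > 100 umol/kg

In a functional assay on the whole organism with Rattus norvegicus as the target (a lower number here means that less compound is needed, a higher number that more compound is needed for the effect), compound 1 gives only a limit, > 100 umol/kg, and not a number. Compound 2 likewise returns only a limit in this assay, > 100 umol/kg. Where compound 1 stands is therefore unknown beyond (the limit of > 100 umol/kg in this assay, at which 2 of the 2 values shown sit), and the two values show no difference between them.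

Compound 3, `CNN=C1CCC(C)n2c1ncc(C(=O)O)c2=O`, has not been run in this assay. It differs from compound 1 by methyl in place of 2,3-dimethylphenyl on an amine nitrogen. Within the data shown here, no step between measured compounds is known, so the size of this change cannot be read from the series; the expectation is no step beyond the scatter, with compound 3 staying at the limit as well, so the step from compound 1 to compound 3 is expected to be a step that the limit leaves unreadable from compound 1 to compound 3. Compound 3 is accordingly estimated at 150 umol/kg, within 60 umol/kg to 500 umol/kg, most probably again reported only as a limit.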

Compound 3, dose for 50% inhibition: > 100 umol/kg
Compound 3 ended at the assay's limit; the forecaster's own chance of this, stated with the estimate: 70%; the middle value does not contradict the limit.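

Compound 1 and compound 3 both stop at a limit rather than a number in this assay, so no step between them can be read: the limit of > 100 umol/kg in this assay, at which 3 of the 3 values shown sit.

The compounds shown leave open what dose gives the effect for any of them, and whether methyl and 2,3-dimethylphenyl on an amine nitrogen differ at all.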